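Shortening the Amine Side Chain on the Shared Core

The source may report more compounds than this note shows. Statements on the series, on what has been measured and on what is new or still open speak of the compounds shown alone.

Compound 1 `c1ccc(CN(CCCCN(C[C@H]2Cc3ccccc3CN2)[C@H]2CCCc3cccnc32)Cc2ccccn2)nc1` gives only the limit > 30000 nM in a functional assay on cells for agonist activity at C-X-C chemokine receptor type 4 (Homo sapiens), read by fluorescence and calcium flux, with a stated time of 90 s; on this read-out lower numbers stand for an effect already at smaller amounts and higher numbers for an effect only at larger amounts of compound. Compound 2 `c1cncc(CN(CCCCN(C[C@H]2Cc3ccccc3CN2)[C@H]2CCCc3cccnc32)Cc2cccnc2)c1` likewise gives only the limit > 30000 nM. Compound 3 `c1ccc2c(c1)CN[C@@H](CN(CCCCNC1CCOCC1)[C@H]1CCCc3cccnc31)C2` gives only the limit > 30000 nM.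

Compound 3 therefore stands nowhere in particular among the numbers shown: every value is a limit of the assay, (the limit of > 30000 nM in this assay, at which 3 of the 3 values shown sit), and no compound can be ranked against another on this evidence. For the measured compounds named here, no step between measured compounds is available to calibrate the change that leads to compound 4 `CC(C)(CN)CCN(C[C@H]1Cc2ccccc2CN1)[C@H]1CCCc2cccnc21`. The difference is 1-(aminomethyl)-1-methylethyl in place of 2-((oxan-4-yl)amino)ethyl on a saturated chain carbon, two bonds along the chain from an amine nitrogen. With all three measured compounds sitting at the same limit, the change is expected to produce no step beyond the scatter, and compound 4 is expected to remain at the limit as well, so the expected step is a number no higher from compound 3 to compound 4 (the limit leaves the size open). Compound 4 is estimated at 30000 nM, within 10000 nM to 100000 nM.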

Compound 4, half-maximal effective concentration: > 30000 nM
Compound 4 ended at the assay's limit; the forecaster's own chance of this, stated with the estimate: 75%; the middle value lies on the limit itself.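

For the compounds shown here, no step from compound 3 to compound 4 can be read in this assay, because both values are limits of the assay and not numbers: the limit of > 30000 nM in this assay, at which 4 of the 4 values shown sit.

The compounds shown leave open how far each lies beyond that limit, and whether any change on the shared core would give a measurable value.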